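A few compounds are considered here, and "the series" means these few. Any claim that something is new, unique, unknown or untested is made for them only; others in the source may bear on it.

Of the compounds shown here, two built on a shared coumarin-type core have been measured so far. Compound 1 `O=C(NC1CCCCC1)c1cc2ccccc2oc1=O` carries a cyclohexyl group on the amide nitrogen, and in an in vitro assay on BTI-TN-5B1-4 cells for inhibition of Amine oxidase [flavin-containing] B (Homo sapiens), read by fluorescence (on this read-out higher numbers stand for weaker inhibition and lower numbers for stronger inhibition), compound 1 gives 500 nM. Compound 2 `CC(C)c1ccc(NC(=O)c2cc3ccccc3oc2=O)cc1` carries an aromatic ring bearing an isopropyl group instead, and in this assay compound 2 gives 650 nM. Of the two numbers measured, compound 2 and compound 1 sit within the usual scatter of each other, so nothing separates them beyond the noise of repeated measurement.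

Compound 3 `O=C(Nc1ccc(O)cc1)c1cc2ccccc2oc1=O` has not yet been measured. It differs from compound 2 in one place: hydroxy in place of isopropyl on an aromatic carbon. Within the data shown here, no measured pair shows what this kind of exchange does on this core, so the expectation rests only on the fact that both measured compounds sit close together.

The step from compound 2 to compound 3 in this assay is expected to be a modest weakening, about a 1.8-fold higher number from compound 2 to compound 3 (0.27 log units; within the scatter). Compound 3 is therefore expected to give roughly 1200 nM, with a plausible range from 400 nM to 4000 nM.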

Compound 3, half-maximal inhibitory concentration: 800 nM
Beside the measured number, compound 3's estimate is 1.5-fold (0.18 log units) above it; low and high end bracket the measured number.
By their numbers in this assay, from the lowest: compounds 1, 2 and 3 (each within the scatter of the next).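

Hydroxy in place of isopropyl on an aromatic carbon, para to a large group, is the first exchange at this place on the ring, and in this assay it gives a 1.2-fold higher number from compound 2 to compound 3 (0.09 log units; within the scatter). This place therefore accepts either isopropyl, with 3 heavy atoms and no hydrogen-bond donor or acceptor, or hydroxy, with 1 heavy atom, 1 hydrogen-bond donor and 1 hydrogen-bond acceptor, without a difference that stands clear of the noise of repeated measurement. Changing the group on the amide-type nitrogen, with 4-hydroxyphenyl in place of cyclohexyl, gives a 1.6-fold higher number from compound 1 to compound 3 (0.20 log units; within the scatter), so this wider exchange also stays within the scatter, and no supporting data explain why either exchange leaves the numbers so close.

As far as these compounds go, whether an amine, a carboxylic acid or a methoxy group on the same aromatic carbon would produce a step beyond the scatter remains open. Also open, from the compounds shown here alone, is whether a longer chain on the amide-type nitrogen, or hydroxy on a different carbon of the aromatic ring, would separate from these three compounds.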